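Furan-3-yl for furan-2-yl on a shared nucleoside core

A few compounds are considered here, and "the series" means these few. Any claim that something is new, unique, unknown or untested is made for them only; others in the source may bear on it.

Measured compounds in a functional assay on CEM-DNR-bulk cells (Homo sapiens), read by MTT assay, with a stated time of 72 h; a lower number here means a stronger inhibitor, a higher number a weaker inhibitor:
Compound 1, `Cc1ncnc2c1c(-c1cccs1)cn2[C@@H]1O[C@H](CO)[C@@H](O)[C@H]1O`: > 20000 nM
Compound 2, `Nc1nc2c(c(-c3ccco3)cn2[C@@H]2O[C@H](CO)[C@@H](O)[C@H]2O)c(=O)[nH]1`: > 20000 nM
Compound 3, `Nc1nc(N)c2c(-c3ccco3)cn([C@@H]3O[C@H](CO)[C@@H](O)[C@H]3O)c2n1`: > 20000 nM

Each of these values is a limit of the assay rather than a number. Within the data shown here, compound 2 stands at that limit, (the limit of > 20000 nM in this assay, at which 3 of the 3 values shown sit), and its two neighbours stand there as well, so nothing among the measured compounds separates one from another in this assay.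

Compound 4, `Nc1nc2c(c(-c3ccoc3)cn2[C@@H]2O[C@H](CO)[C@@H](O)[C@H]2O)c(=O)[nH]1`, keeps the core of compound 2 and differs from it in one place: furan-3-yl in place of furan-2-yl on an aromatic carbon.

Among the measured compounds shown here, with every measured value a limit and no measured step on which to rest, the account expects no effect of this change beyond the usual scatter. The expected step of a number no higher from compound 2 to compound 4 (the limit leaves the size open) in this assay is therefore none of note, with the most likely outcome a further limit. For compound 4 the estimate in this assay is 20000 nM, in the range 5000 nM to 60000 nM.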

Compound 4, half-maximal inhibitory concentration: 15000 nM
Compound 4: the middle estimate sits 1.3-fold (0.12 log units) above what was measured; measured number inside the range.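

In this assay, among these compounds, compound 4 gives 15000 nM, the only value in this set that is a number rather than a limit, so a compound with a ring at this aromatic carbon can read within the range of the assay. Compound 2 gives > 20000 nM, which is a limit. Furan-3-yl in place of furan-2-yl gives an at least 1.3-fold lower number from compound 2 to compound 4 (0.12 log units; that floor lies within the scatter), so the true size of the change stays open, as the comparison rests on a limit: the limit of > 20000 nM in this assay, at which 3 of the 4 values shown sit.

On these data alone, whether furan-3-yl would also give a number on the core of compound 3 remains open. As far as these compounds go, how a phenyl ring, an amine or a carboxylic acid at this position would read in this assay also remains open.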